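The source may report more compounds than this note shows. Statements on the series, on what has been measured and on what is new or still open speak of the compounds shown alone.

In an ADME assay on MT2 cells (Homo sapiens) for cytotoxicity, read by XTT assay, with a stated time of 4 days (a lower number here means that less compound is tolerated, a higher number that more compound is tolerated), compound 2 (`Cc1nc(C(NC(=O)C(=O)Nc2ccc(Cl)cc2)C2CCCCN2)sc1CO`) gives > 108000 nM and that figure is a limit of the assay, not a number. Compound 1 (`Cc1nc(C(NC(=O)C(=O)Nc2ccc(Cl)cc2)C2CCNCC2)sc1CO`) gives > 81000 nM and this is also a limit. Compound 3 (`Cc1nc(C(NC(=O)C(=O)Nc2ccc(Cl)cc2)C2CCCNC2)sc1CO`) gives > 81000 nM and this is a limit as well.

Compound 4 (`Cc1ccc(NC(=O)C(=O)NC(c2nc(C)c(CO)s2)C2CCCCN2)cc1F`) has 3-fluoro-4-methylphenyl in place of the 4-chlorophenyl of compound 2 on an amide-type nitrogen (3-fluoro-4-methylphenyl in place of 4-chlorophenyl on an amide-type nitrogen).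

Among the measured compounds shown here, no measured step makes this exact swap. The closest are a step that the two limits leave unreadable from compound 1 to compound 2 and a step that the two limits leave unreadable from compound 1 to compound 3 and a step that the two limits leave unreadable from compound 2 to compound 3 and all three only move the piperidine while 4-chlorophenyl stays in place. Their sizes cannot be read, which leaves them a weak guide.

In this assay no step beyond the usual scatter is expected, in either direction. This expectation rests on the limit of compound 2 at > 108000 nM and on the matching limits of its two relatives. The estimated change is an at least 1.0-fold lower number from compound 2 to compound 4 (0.03 log units; that floor lies within the scatter) and no larger shift is foreseen. For compound 4 the expected value is 100000 nM (estimated range 40000 nM to 200000 nM).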

Compound 4, half-maximal cytotoxic concentration: > 88000 nM
Compound 4 ended at the assay's limit; the forecaster's own chance of this, stated with the estimate: 80%; the middle value does not contradict the limit.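

In this assay, compound 2 and compound 4 both give limits of the assay rather than numbers, and no step can be read between them. The compounds shown leave open at what concentration any of them would become toxic to these cells.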